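A few compounds are considered here, and "the series" means these few. Any claim that something is new, unique, unknown or untested is made for them only; others in the source may bear on it.

Measured so far in an assay on isolated protein for agonist activity at Free fatty acid receptor 1 (Homo sapiens); on this read-out higher numbers stand for an effect only at larger amounts of compound and lower numbers for an effect already at smaller amounts:
compound 1 `CC#CC(CC(=O)O)c1ccc(OCc2ccn3cc(-c4ccc(C)cc4)nc3c2)cc1`, 618 nM
compound 2 `CC#CC(CC(=O)O)c1ccc(OCc2ccn3cc(-c4cccc(C)c4)nc3c2)cc1`, 1510 nM
compound 3 `CC#CC(CC(=O)O)c1ccc(OCc2ccn3cc(-c4ccc(C(F)(F)F)cc4)nc3c2)cc1`, 674 nM

Compound 3 stands second highest of the three numbers. Its value lies within the scatter of compound 1 (a 1.1-fold higher number from compound 1 to compound 3 (0.04 log units; within the scatter)) and beyond the scatter below compound 2 (a 2.2-fold lower number from compound 2 to compound 3 (0.35 log units; beyond the scatter)). Compound 4 `CC#CC(CC(=O)O)c1ccc(OCc2ccn3cc(-c4cc(F)ccc4F)nc3c2)cc1` is not yet measured. The change from compound 3 is 2,5-difluorophenyl in place of 4-(trifluoromethyl)phenyl on an aromatic carbon.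

For the measured compounds named here, no measured step swaps the whole substitution pattern of this phenyl in one go, so the bearing steps are indirect. a 1.1-fold higher number from compound 1 to compound 3 (0.04 log units; within the scatter) shows that trifluoromethyl for methyl leaves the number unchanged within the scatter when the 4-methylphenyl becomes 4-(trifluoromethyl)phenyl. a 2.4-fold higher number from compound 1 to compound 2 (0.39 log units; beyond the scatter) and a 2.2-fold lower number from compound 2 to compound 3 (0.35 log units; beyond the scatter) show that 3-methylphenyl gives a modestly higher number than either 4-methylphenyl or 4-(trifluoromethyl)phenyl. Going by the values given here, compound 4 carries neither a methyl nor a trifluoromethyl and bears two fluorines instead; the nearest precedent is the modest loss seen with compound 2. A modest rise in the number is therefore expected, a 1.6-fold higher number from compound 3 to compound 4 (0.21 log units; within the scatter), though a result within the scatter cannot be excluded. For compound 4 the estimate in this assay is 1100 nM, with a range from 500 nM to 2500 nM.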

Compound 4, half-maximal effective concentration: 639 nM
Estimate against measurement, compound 4: 1.7-fold (0.24 log units) above; the measured number falls inside the stated range.
By their numbers in this assay, from the lowest: compounds 1, 4 and 3 (each within the scatter of the next); then compound 2.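

In this assay, the replacement of 4-(trifluoromethyl)phenyl by 2,5-difluorophenyl gives a 1.1-fold lower number from compound 3 to compound 4 (0.02 log units; within the scatter), and the replacement of 4-methylphenyl by the same group gives a 1.0-fold higher number from compound 1 to compound 4 (0.01 log units; within the scatter), so this aromatic carbon of the five-membered ring accepts a phenyl with two fluorines and no carbon substituent without a change beyond the scatter. Against 3-methylphenyl, the same group gives a 2.4-fold lower number from compound 2 to compound 4 (0.37 log units; beyond the scatter), which leaves 3-methylphenyl as the only one of the four phenyl groups here set apart from the others, although the series holds just this one example of that kind. Nothing available bears on why these phenyl groups give such similar numbers.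

The two fluorines enter together, so the compounds shown leave open what either one contributes alone, and whether a single fluorine at either place would give a number in the same range. Also open, on these data alone, is whether an amine, a carboxylic acid or a longer alkyl chain on this phenyl would give a number beyond the scatter of compound 1, compound 3 and compound 4.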